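Urea to amide at the anilide carbonyl: compound 4

This account rests on a few compounds, and the source may have more. Where it says the series, first, only, none or still open, it means among the compounds named here.

Three members of the series have been measured in a functional assay on MDA-MB-435 cells (Homo sapiens) for inhibition, read by sulforhodamine B assay, with a stated time of 48 h, tested at 10 uM; on this read-out lower numbers stand for a stronger effect and higher numbers for a weaker effect at the one concentration tested. Compound 1 `O=C(Nc1cccc(-n2cc(-c3ccncc3)c(-c3cc(O)cc(Cl)c3)n2)c1)Nc1ccc(Cl)c(C(F)(F)F)c1` gives 9.57%, compound 2 `COc1cc(Cl)cc(-c2nn(-c3cccc(NC(=O)Nc4ccc(Cl)c(C(F)(F)F)c4)c3)cc2-c2ccncc2)c1` gives -16.8%, and compound 3 `COc1cc(Cl)cc(-c2nn(-c3cccc(NC(=O)Nc4cc(C(F)(F)F)cc(C(F)(F)F)c4)c3)cc2-c2ccncc2)c1` gives -19.5%. Compound 2 thus stands second highest of the three; its nearest neighbour is compound 3, within the scatter, and its furthest is compound 1, beyond the scatter. Among the compounds with values here, the one step that differs in a single place is a number 26.4 percentage points lower from compound 1 to compound 2 (beyond the scatter).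

Compound 4 `COc1cc(Cl)cc(-c2nn(-c3cccc(NC(=O)c4cccc(C(F)(F)F)c4)c3)cc2-c2ccncc2)c1` is the unmeasured member. It departs from compound 2 by 3-(trifluoromethyl)phenyl in place of (4-chloro-3-(trifluoromethyl)phenyl)amino on a carbonyl carbon. Within the data shown here, no measured step touches this position in a comparable way: the step from compound 1 to compound 2 concerns the oxygen on the aromatic ring, and compounds 2 and 3, which differ in the aryl on the urea, show only two values lying within the scatter of each other. The effect of the change is therefore open. In this assay compound 4 is expected at about 5%, within -20% to 35%, which would mean an estimated step of a number 21.8 percentage points higher from compound 2 to compound 4 (beyond the scatter) and is drawn wide for want of precedent.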

Compound 4, a percentage reported as activity, at one concentration (the size of the read-out at that concentration, not a potency): 65.6%
The estimate for compound 4 lay 60.6 percentage points below the measured number; measured number outside the range, above it.
By their numbers in this assay, from the lowest: compounds 3 and 2 (each within the scatter of the next); then compound 1; then compound 4.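

In this assay, the carbonyl carbon's substituent proves highly sensitive to change: a number 82.4 percentage points higher from compound 2 to compound 4 (beyond the scatter), a large step. For this pair, replacing the urea with the amide gives a much weaker effect at the one concentration tested, so the (4-chloro-3-(trifluoromethyl)phenyl)amino group cannot be exchanged for 3-(trifluoromethyl)phenyl without a clear cost. No supporting data are available to account for the size of this step.

The change removes the amino nitrogen, with its hydrogen-bond donor, and the chlorine together, so the compounds shown do not assign the step to either one. Still open, on these data alone, is how an amide carrying 4-chloro-3-(trifluoromethyl)phenyl on the carbonyl carbon would read, and whether a methylene in place of the amino nitrogen would keep the effect of compound 2.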